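Propyl for fluoromethyl on the amide aryl of compound 2

The compounds below may be only part of what the source reports. "The series", "measured", "known", "first", "only" and "open" are said of these compounds alone.

The measured compounds:
Compound 1 `Cc1ccc(C(=O)Nc2cccc(-c3oc4cc(-c5ccc(F)cc5)ccc4c(=O)c3O)c2)cc1` gives 2400 nM in a functional assay on MCF7 cells (Homo sapiens) for antiproliferative activity, read by CCK-8 assay, with a stated time of 72 h; on this read-out lower numbers stand for stronger inhibition and higher numbers for weaker inhibition.
Compound 2 `Cc1cc(C(=O)Nc2cccc(-c3oc4cc(-c5ccc(F)cc5)ccc4c(=O)c3O)c2)ccc1F` gives 7710 nM in this assay.

Going by the values given here, on the two numbers in hand, compound 2 stands highest, with the one step of a 3.2-fold higher number from compound 1 to compound 2 (0.51 log units; beyond the scatter) separating it from compound 1, which therefore sits at the lower end of this small set.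

Compound 3 `CCCc1ccc(C(=O)Nc2cccc(-c3oc4cc(-c5ccc(F)cc5)ccc4c(=O)c3O)c2)cc1` has not been measured. It differs from compound 2 by 4-propylphenyl in place of 4-fluoro-3-methylphenyl on a carbonyl carbon. Among the compounds with values here, only one measured step bears on the change: the step of a 3.2-fold higher number from compound 1 to compound 2 (0.51 log units; beyond the scatter), which replaced 4-methylphenyl with 4-fluoro-3-methylphenyl and raised the number beyond the scatter. Compound 3 carries a 4-propylphenyl group, which, like the 4-methylphenyl of compound 1, has no fluorine and one alkyl chain; for this reason the step from compound 2 is expected to run downward, back toward the number of compound 1, though the propyl chain is longer than methyl and the exact size of this reversal is uncertain. The expected step is a 2.6-fold lower number from compound 2 to compound 3 (0.41 log units; beyond the scatter). Compound 3 is thus estimated to give 3000 nM in this assay, within a range of 1000 nM to 9000 nM.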

Compound 3, half-maximal inhibitory concentration: 36800 nM
The estimate for compound 3 lay 12-fold (1.09 log units) below the measured number, outside the stated range (above it).
By their numbers in this assay, from the lowest: compound 1; then compound 2; then compound 3.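

In this assay the position on the carbonyl carbon proved sensitive to chain length alone: ethyl in place of hydrogen on the saturated chain carbon, which turns 4-methylphenyl into 4-propylphenyl, gave a 15-fold higher number from compound 1 to compound 3 (1.19 log units; beyond the scatter) and was the largest step among these compounds. Replacing 4-fluoro-3-methylphenyl with 4-propylphenyl gave a 4.8-fold higher number from compound 2 to compound 3 (0.68 log units; beyond the scatter) and so moved the number further from that of compound 1, which shows that a single alkyl chain without fluorine does not by itself restore the lower number. No accompanying measurement speaks to why the number rose with the longer chain.

The three compounds leave open whether the number rises steadily with each added carbon or turns sharply at one chain length, which a 4-ethylphenyl or 4-butylphenyl group on the same carbonyl carbon would help to settle. They also leave open whether a propyl-length chain ending in an amine or a carboxylic acid would behave like the 4-propylphenyl group of compound 3 or move the number the other way.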